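Trading Methyl for Hydroxy in a Fatty Acid Receptor Agonist Series

This account rests on a few compounds, and the source may have more. Where it says the series, first, only, none or still open, it means among the compounds named here.

Of the compounds shown here, three have so far been tested in a functional assay on CHO cells for agonist activity at Free fatty acid receptor 1 (Homo sapiens), read by reporter gene assay; on this read-out higher numbers stand for larger maximal responses and lower numbers for smaller maximal responses. Compound 2 `Cc1ccc(CNc2ccc(CCC(=O)O)cc2)cc1` reaches 152%, the highest of the three. Compound 1 `O=C(O)C1CC1c1ccc(NCc2cccc(Oc3ccccc3)c2)cc1` gives 74%, beyond the scatter below compound 2, and compound 3 `O=C(O)CCc1ccc(NCc2cccnc2)cc1` gives 4%, further below still. Compound 4 `O=C(O)CCc1ccc(NCc2ccc(O)cc2)cc1` differs from compound 2 in one place: hydroxy in place of methyl on an aromatic carbon. Within the data shown here, no pair of measured compounds shows this exchange, so the expectation rests on the spread seen so far. A downward step in this assay is expected, since compound 3 gives only 4% with a different outer ring. Compound 4 is expected to give 90%, within 30% to 150%. This amounts to an expected step of a number 62 percentage points lower from compound 2 to compound 4 (beyond the scatter).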

Compound 4, largest response reached (reported as percent of maximum), in percent of the reference or control that the assay uses: 37%
Compound 4: middle estimate off by 53 percentage points, on the high side, and the stated range covers the measured number.
By their numbers in this assay, from the lowest: compound 3; then compound 4; then compound 1; then compound 2.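

In this assay, this position proves highly sensitive to a one-atom change: hydroxy in place of methyl, para to a large group, gives a number 115 percentage points lower from compound 2 to compound 4 (beyond the scatter). The heavy-atom count stays the same, while the entering group brings one hydrogen-bond donor and one hydrogen-bond acceptor. Nothing available explains why the response falls. The compounds shown leave open how methoxy, an amine or chlorine at this same place would compare with methyl and hydroxy. They also leave open whether this exchange would have a similar effect on the core of compound 1.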